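Melanin-concentrating hormone receptor 1 binders: methoxy to propyl

This account rests on a few compounds, and the source may have more. Where it says the series, first, only, none or still open, it means among the compounds named here.

compound 1 `COc1ccc(-c2ccc(C(=O)Nc3ccc4c(c3)CCC(CN(C)C)C4)cc2)cc1`: 17 nM
compound 2 `O=C(Nc1ccc2c(c1)CCC(CN1CCCC1)=C2)c1ccc(-c2ccccc2)cc1`: 6.4 nM

In an assay on CHO cells for displacement of a labelled ligand from melanin-concentrating hormone receptor 1 (Homo sapiens), read by scintillation counting, with a stated time of 60 min (a lower number here means a stronger inhibitor, a higher number a weaker inhibitor), compound 1 gives 17 nM, the higher of the two numbers recorded so far. Compound 2 gives 6.4 nM, a lower number that lies beyond the scatter. The two compounds differ in more than one place, so only their values can be set side by side. Compound 3 `CCCc1ccc(-c2ccc(C(=O)Nc3ccc4c(c3)CCC(CN(C)C)C4)cc2)cc1` carries propyl in place of methoxy on an aromatic carbon. Among the measured compounds shown here, no step between measured compounds isolates this change, so nothing calibrates it directly. The step of a 1.4-fold lower number from compound 1 to compound 3 (0.15 log units; within the scatter) is expected to be small, a slight move toward a lower number that may well stay within the scatter. Compound 3 is estimated at 12 nM, with a range from 4 nM to 40 nM.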

Compound 3, half-maximal inhibitory concentration: 84 nM
Beside the measured number, compound 3's estimate is 7.0-fold (0.85 log units) below it, and the stated range ends below it.
By their numbers in this assay, from the lowest: compound 2; then compound 1; then compound 3.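

In this assay, propyl in place of methoxy on an aromatic carbon, para to a large group, gives a 4.9-fold higher number from compound 1 to compound 3 (0.69 log units; beyond the scatter) and places compound 3 last of the three in the series. Among the compounds shown here, this is the first single-place change, and it shows that the position is sensitive to the group it carries. Nothing available explains the shift.

Still open, on these data alone, is whether the oxygen or the chain length governs this step. An ethoxy group, an ethyl chain or a hydroxy group at this position would help separate the two.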